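Bromo for Chloro: Growth Inhibition Expected to Stay Low

This account rests on a few compounds, and the source may have more. Where it says the series, first, only, none or still open, it means among the compounds named here.

For the measured compounds named here, compound 1 `O=C1NC(=S)/C(=C/c2cccc(Cl)c2)S1` gives 3.35% in a functional assay on NCI-H292 cells (Homo sapiens) for cytotoxicity, read by MTT assay, with a stated time of 72 h, tested at 1.25 ug/mL (on this read-out lower numbers stand for less inhibition of growth and higher numbers for more inhibition of growth at the one concentration tested), the lowest of the two numbers measured so far. Compound 2 `O=C1NC(=S)/C(=C/c2ccccc2Cl)S1` gives 10.6% in this assay, a reading within the scatter of compound 1. Compound 3 `O=C1NC(=S)/C(=C/c2cccc(Br)c2)S1` differs from compound 1 by bromo in place of chloro on an aromatic carbon. Going by the values given here, no step of this kind has been measured here, and both known readings are low, so the change is expected to shift the number by little, if at all, beyond the scatter. Compound 3 is expected to give 6%, between 0% and 18%. The expected step is a number 2.7 percentage points higher from compound 1 to compound 3 (within the scatter).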

Compound 3, percent growth inhibition at one concentration: 4.67%
Compound 3: the middle estimate sits 1.3 percentage points above what was measured, and the stated range covers the measured number.
By their numbers in this assay, from the lowest: compounds 1, 3 and 2 (each within the scatter of the next).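

Bromo in place of chloro on an aromatic carbon gives the first one-place step in this assay, a number 1.3 percentage points higher from compound 1 to compound 3 (within the scatter), and it shows that at this place on the ring, compound 1 and compound 3 cannot be told apart on this read-out. Nothing measured here accounts for this result. The compounds shown leave open whether an amine or a carboxylic acid at this place would read any differently from either halogen. They also leave open whether bromo would match chloro at the ring place where compound 2 carries its chloro.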